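Changing one carbonyl group on compound 2

The source may hold more compounds than are shown below. What is called first, only, known or untested is meant among the compounds shown, and "the series" means these compounds.

Measured in a functional assay on Shh Light II cells (Mus musculus) for inhibition, read by a luciferase reporter; a lower number here means a stronger inhibitor, a higher number a weaker inhibitor:
- compound 1 `O=C(N1CCC(c2nc(-c3ccc4ccccc4n3)no2)CC1)N1CCCc2ccccc21`: 2300 nM
- compound 2 `O=C(NC1CCS(=O)(=O)CC1)N1CCC(c2nc(-c3ccc4ccccc4n3)no2)CC1`: 360 nM

Of these two, compound 2 has the lower number and is the stronger inhibitor. Compound 3 `O=C(OC1CCCCC1)N1CCC(c2nc(-c3ccc4ccccc4n3)no2)CC1` carries cyclohexyloxy in place of (1,1-dioxothian-4-yl)amino on a carbonyl carbon.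

Going by the values given here, only one measured step bears on this place, the modest 6.4-fold lower number from compound 1 to compound 2 (0.81 log units; beyond the scatter). It shows that this place can move the number, but it does not test cyclohexyloxy. Among the compounds with values here, compound 2 at 360 nM holds the lowest number so far, so a modest rise is the expectation in this assay. The expected change is a 1.9-fold higher number from compound 2 to compound 3 (0.29 log units; within the scatter). For compound 3 the estimate is 700 nM, with an expected range of 130 nM to 3500 nM.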

Compound 3, half-maximal inhibitory concentration: 580 nM
Estimate against measurement, compound 3: 1.2-fold (0.08 log units) above; measured number inside the range.
By their numbers in this assay, from the lowest: compounds 2 and 3 (each within the scatter of the next); then compound 1.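

In this assay, the swap to cyclohexyloxy gives a 1.6-fold higher number from compound 2 to compound 3 (0.21 log units; within the scatter), so this position keeps its number with a carbon-only ring and no hydrogen-bond donor in place of (1,1-dioxothian-4-yl)amino. The same group gives a 4.0-fold lower number from compound 1 to compound 3 (0.60 log units; beyond the scatter), which leaves 1,2,3,4-tetrahydroquinolin-1-yl as the poorer of the three groups at this carbonyl carbon. Nothing available explains these differences.

Cyclohexylamino would show whether the linking oxygen matters apart from the ring. Going by these compounds, whether an open chain such as n-hexyloxy, or a small methoxy, holds the number remains open.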